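The source may report more compounds than this note shows. Statements on the series, on what has been measured and on what is new or still open speak of the compounds shown alone.

In a functional assay on HeLa cells (Homo sapiens) for inhibition (a lower number here means a stronger inhibitor, a higher number a weaker inhibitor), compound 1 `CC(=O)OC(C)n1cnc2c(Cl)nc(I)nc21` gives 5130 nM. Compound 3 `CC(=O)OC(C)n1cnc2c(Cl)nc(F)nc21` carries fluoro where compound 1 carries iodo. In this assay compound 3 gives 50000 nM, the higher of the two numbers measured, the step being a 9.7-fold higher number from compound 1 to compound 3 (0.99 log units; beyond the scatter). Compound 2 `CC(=O)OC(C)n1cnc2c(N)nc(I)nc21` gives > 500000 nM, which is the limit of > 500000 nM in this assay, at which 1 of the 3 values shown sits, a limit of this assay and not a number. Compound 4 `CC(=O)OC(C)n1cnc2c(S)nc(F)nc21` differs from compound 3 in one place: sulfanyl in place of chloro on an aromatic carbon. Going by the values given here, the one measured step at that same aromatic carbon, an at least 97-fold higher number from compound 1 to compound 2 (1.98 log units; beyond the scatter), was large and toward a weaker inhibitor, so a step in the same direction is expected for compound 4 in this assay. Compound 4 is therefore estimated at 200000 nM, within a range from 50000 nM to 500000 nM, which would mean a 4.0-fold higher number from compound 3 to compound 4 (0.60 log units; beyond the scatter), with a fair chance that only a limit is reported.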

Compound 4, half-maximal inhibitory concentration: > 500000 nM
Compound 4 ended at the assay's limit (the forecaster's own chance of this, stated with the estimate: 45%); at least 2.5-fold (0.39 log units) between middle value and limit.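

In this assay, an at least 10-fold higher number from compound 3 to compound 4 (1.00 log units; beyond the scatter) shows that replacing chloro on this aromatic carbon weakens inhibition with sulfanyl as well as with amino, and on a fluoro-bearing compound as well as an iodo-bearing one. Compound 4 gives a limit of the assay and not a number, so this step fixes only a minimum size. Compound 4 shares that limit with compound 2, so sulfanyl and amino cannot be ranked: the limit of > 500000 nM in this assay, at which 2 of the 4 values shown sit.

Open, from the compounds shown here alone, is whether bromo, methyl or methoxy on this carbon would keep a number close to that of compound 3, 50000 nM.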